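Chloro on the aromatic ring of the cyclopropyl amide

The compounds below may be only part of what the source reports. "The series", "measured", "known", "first", "only" and "open" are said of these compounds alone.

Measured compounds:
Compound 1 `C#CCNC(=O)/C(C)=C(\C)c1ccc(Cl)cc1`, 400 mg/kg in a toxicity assay on the whole organism (strain Icem-CET (SPF Caw)) for cytotoxicity, with Mus musculus as the target; a lower number here means that less compound is needed, a higher number that more compound is needed for the effect
Compound 2 `C/C(C(=O)NC1CC1)=C(/C)c1ccccc1`, 250 mg/kg

Compound 2 stands alongside compound 1 in this assay, the two numbers within the scatter of each other, so neither can be ranked against the other. Compound 3 `C/C(C(=O)NC1CC1)=C(/C)c1ccc(Cl)cc1` differs from compound 2 by chloro in place of hydrogen on an aromatic carbon, and carries the same chlorinated ring as compound 1. Among the measured compounds shown here, no measured pair isolates this change, so the step of a 1.2-fold higher number from compound 2 to compound 3 (0.08 log units; within the scatter) is expected to be small and to stay within the scatter. The value estimated for compound 3 in this assay is 300 mg/kg, between 150 mg/kg and 600 mg/kg.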

Compound 3, dose for half-maximal effect: > 800 mg/kg
Compound 3: a limit, no number (the forecaster's own chance of this, stated with the estimate: 5%); middle value at least 2.6-fold (0.42 log units) away from the limit.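

In this assay compound 3 carries a limit and not a number: the limit of > 800 mg/kg in this assay, at which 1 of the 3 values shown sits. Even so, chloro in place of hydrogen on an aromatic carbon, para to a large group, proves to be a clear change on the cyclopropyl amide, with an at least 3.2-fold higher number from compound 2 to compound 3 (0.50 log units; beyond the scatter) as its step. Cyclopropyl in place of propargyl on the amide nitrogen gives an at least 2.0-fold higher number from compound 1 to compound 3 (0.30 log units; that floor lies within the scatter), so the size of that change remains unsettled. The compounds shown leave open how far past its limit compound 3 lies. They also leave open whether fluoro, methyl or methoxy at this ring position would shift the number as chloro does.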